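Replacing the trimethoxyphenyl on the hydrazone carbon

The compounds below may be only part of what the source reports. "The series", "measured", "known", "first", "only" and "open" are said of these compounds alone.

Measured so far in a functional assay on MKN-45 cells (Homo sapiens) for cytotoxicity, read by MTT assay, with a stated time of 72 h; on this read-out higher numbers stand for weaker inhibition and lower numbers for stronger inhibition:
compound 1 `CN(C)CCn1cnnc1-c1cc(Oc2ccc(NC(=O)N/N=C/c3cccc(Cl)c3Cl)cc2F)ccn1` gives 51 nM
compound 2 `CN(C)CCn1cnnc1-c1cc(Oc2ccc(NC(=O)N/N=C/c3ccc(F)cc3)cc2F)ccn1` gives 1030 nM
compound 3 `COc1cc(/C=N/NC(=O)Nc2ccc(Oc3ccnc(-c4nncn4CCN(C)C)c3)c(F)c2)cc(OC)c1OC` gives 2900 nM

All three share one core and differ only in the aryl group on a carbon with a double bond to nitrogen. On these numbers compound 3 gives the highest value of the three: compound 2 comes nearest, and compound 1 is the furthest away, as a 2.8-fold higher number from compound 2 to compound 3 (0.45 log units; beyond the scatter) and a 57-fold higher number from compound 1 to compound 3 (1.75 log units; beyond the scatter) show.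

Compound 4 `CN(C)CCn1cnnc1-c1cc(Oc2ccc(NC(=O)N/N=C/c3ccc(O)cc3O)cc2F)ccn1` is not yet measured. 2,4-dihydroxyphenyl in place of 3,4,5-trimethoxyphenyl on a carbon with a double bond to nitrogen

Going by the values given here, two steps bear on this change, and both say that the group at this position matters: a 57-fold higher number from compound 1 to compound 3 (1.75 log units; beyond the scatter) and a 2.8-fold higher number from compound 2 to compound 3 (0.45 log units; beyond the scatter). The step of a 20-fold higher number from compound 1 to compound 2 (1.31 log units; beyond the scatter) shows that swapping one small aryl group for another can also move the number a lot. Nothing measured here carries a 2,4-dihydroxyphenyl, so the direction can only be guessed from the fact that compound 3 stands highest; in this assay compound 4 is expected to come out somewhat lower, by about a 2.9-fold lower number from compound 3 to compound 4 (0.46 log units; beyond the scatter). The estimate for compound 4 in this assay is 1000 nM, with a range from 250 nM to 4000 nM.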

Compound 4, half-maximal inhibitory concentration: 2860 nM
Compound 4: middle estimate off by 2.9-fold (0.46 log units), on the low side, within the range that was stated.
By their numbers in this assay, from the lowest: compound 1; then compound 2; then compounds 4 and 3 (each within the scatter of the next).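

In this assay the step of a 1.0-fold lower number from compound 3 to compound 4 (0.01 log units; within the scatter) shows that this position can take a very different aryl group with no visible change: the 2,4-dihydroxyphenyl has 8 heavy atoms and 2 hydrogen-bond donors, while the 3,4,5-trimethoxyphenyl it replaces has 12 heavy atoms and 0 donors. Compound 4 therefore sits where compound 3 sits relative to the other two, with a 2.8-fold higher number from compound 2 to compound 4 (0.44 log units; beyond the scatter) and a 56-fold higher number from compound 1 to compound 4 (1.75 log units; beyond the scatter) keeping the 2,3-dichlorophenyl group clearly at the low end of the series, so on this evidence swapping oxygen-bearing groups on the ring does not close that gap. No measured property of these groups is available to account for the flat step or for the large one.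

These compounds leave open whether the low number of compound 1 needs both chlorines, which a phenyl ring carrying a single chlorine or a bromine would test. They also leave open how the number would respond to an amine or a carboxylic acid on the same ring.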